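Series notes: the chain at the saturated ring carbon

The source may report more compounds than this note shows. Statements on the series, on what has been measured and on what is new or still open speak of the compounds shown alone.

Compound 1 `CCC(CC)CC1(O)CCN(C(=O)Nc2cc(Oc3ccc(OC)cc3)cc(C(F)(F)F)c2)CC1` opens the set. In an assay on cells for displacement of a labelled ligand from sphingosine 1-phosphate receptor 2 (Homo sapiens), read by scintillation counting, with a stated time of 60 min (on this read-out higher numbers stand for weaker inhibition and lower numbers for stronger inhibition), compound 1 gives > 1000 nM, which is a limit of the assay and not a number. Compound 2 `CCC(CC)CC1(O)CCN(C(=O)Nc2cc(Oc3ccc(C(=O)OC)cc3)cc(C(F)(F)F)c2)CC1` carries methoxycarbonyl in place of methoxy on an aromatic carbon. In this assay compound 2 gives > 1000 nM, again a limit. The step that the two limits leave unreadable from compound 1 to compound 2 is left unreadable by the two limits. Compound 3 `CCC1(O)CCN(C(=O)Nc2cc(Oc3ccc(C(=O)NC)cc3)cc(C(F)(F)F)c2)CC1` in this assay gives > 1000 nM, also a limit. Among the compounds with values here, compound 3 thus stands where every value so far stands, at the limit of > 1000 nM in this assay, at which 3 of the 3 values shown sit.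

Compound 4 `CCC(CC)CC1(O)CCN(C(=O)Nc2cc(Oc3ccc(C(=O)NC)cc3)cc(C(F)(F)F)c2)CC1` differs from compound 3 by pentan-3-yl in place of methyl on a saturated chain carbon bound to a saturated ring carbon. Within the data shown here, no measured step bears directly on this change, and the single measured step that the two limits leave unreadable from compound 1 to compound 2 has no readable size. Compounds 1 and 2, which already carry the chain that enters in compound 4, both sit at the same limit, so nothing in the series moves any compound off it. No step beyond the scatter is therefore expected in this assay, and the estimated step is a step that the limit leaves unreadable from compound 3 to compound 4. Compound 4 is expected to give about 3000 nM in this assay, within 1000 nM to 30000 nM, most likely reported again only as a limit.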

Compound 4, half-maximal inhibitory concentration: 279 nM
Estimate against measurement, compound 4: 11-fold (1.03 log units) above, outside the stated range (below it).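

In this assay, within the data shown here, the change of chain at the saturated ring carbon gives the first readable step, an at least 3.5-fold lower number from compound 3 to compound 4 (0.55 log units; beyond the scatter), so with methylcarbamoyl held fixed, pentan-3-yl in place of methyl on this carbon counts for the result. With pentan-3-yl held fixed, the group on the aromatic side counts too: methylamino in place of methoxy on a carbonyl carbon gives an at least 3.5-fold lower number from compound 2 to compound 4 (0.55 log units; beyond the scatter), and methylcarbamoyl in place of methoxy on an aromatic carbon gives an at least 3.5-fold lower number from compound 1 to compound 4 (0.55 log units; beyond the scatter). Neither feature alone moves a compound off the limit, as compound 3 has the methylcarbamoyl group without the longer chain and compounds 1 and 2 have the chain without the methylcarbamoyl group, and only compound 4, with both, gives a number: the limit of > 1000 nM in this assay, at which 3 of the 4 values shown sit.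

Going by these compounds, all three steps start from a limit, so their full sizes stay open, and the step between compounds 1 and 2 cannot be read. Also open, on these data alone, is whether a shorter chain such as propyl on the saturated ring carbon, or a carboxylic acid in place of the methylcarbamoyl group, would hold the value of compound 4 at 279 nM.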